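The compounds below may be only part of what the source reports. "The series", "measured", "known", "first", "only" and "open" are said of these compounds alone.

Three compounds built on one shared core were tested in a functional assay on MCF7 cells (Homo sapiens) for cytotoxicity, read by MTT assay, with a stated time of 24 h; on this read-out lower numbers stand for stronger inhibition and higher numbers for weaker inhibition. Compound 1 `CCN(CC)C(=S)SCc1nc2cc(Cl)c(Cl)cc2[nH]1` gives 12600 nM in this assay. Compound 2 `CCOc1ccccc1N1CCN(C(=S)SCc2nc3cc(Cl)c(Cl)cc3[nH]2)CC1` gives 16200 nM in this assay. Compound 3 `COc1ccc(N2CCN(C(=S)SCc3nc4cc(C)c(C)cc4[nH]3)CC2)cc1` gives 46000 nM in this assay, the highest of the three numbers; its nearest neighbour is compound 2 and its widest gap is to compound 1, and both gaps lie beyond the usual scatter of repeated measurements. Compound 3 and compound 2 differ in two places at once, so the contribution of each place cannot be read from these numbers alone.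

Compound 4 `CCOc1ccccc1N1CCN(C(=S)SCc2nc3cc(C)c(C)cc3[nH]2)CC1` has not yet been measured in this assay. It differs from compound 3 in a single place: 2-ethoxyphenyl in place of 4-methoxyphenyl on an amine nitrogen in a ring. Going by the values given here, the group that enters is the same one carried by compound 2, whose value of 16200 nM in this assay is lower than that of compound 3, yet compound 2 also carries a different core, so no clean single-change step exists. The expected step of a 1.6-fold lower number from compound 3 to compound 4 (0.22 log units; within the scatter) is a modest move toward a lower number, near the edge of the scatter. Compound 4 is estimated at 28000 nM in this assay, with a range from 12000 nM to 65000 nM.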

Compound 4, half-maximal inhibitory concentration: 5580 nM
Estimate against measurement, compound 4: 5.0-fold (0.70 log units) above; the whole stated range lies above it.
By their numbers in this assay, from the lowest: compound 4; then compounds 1 and 2 (each within the scatter of the next); then compound 3.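

With the core held fixed, replacing 4-methoxyphenyl with 2-ethoxyphenyl on the amine nitrogen in the ring gives, in this assay, an 8.2-fold lower number from compound 3 to compound 4 (0.92 log units; beyond the scatter). Going by these compounds alone, this single-change step shows that the group at this position can alter the cytotoxicity read-out well beyond the usual scatter, which the earlier compounds could not show, as they differed in two places at once. No measurement at hand explains how this change produces the shift.

The change alters both the number in the group's name and the chain, methoxy to ethoxy, so the compounds shown cannot say which of the two matters. A 2-methoxyphenyl or 4-ethoxyphenyl group in the same place would separate them, and a longer chain such as 2-propoxyphenyl would test how far the trend extends.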